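The compounds below may be only part of what the source reports. "The series", "measured", "known", "first", "only" and "open" are said of these compounds alone.

Three compounds have been measured in an assay (strain Wistar) for displacement of a labelled ligand from adenosine receptor A1 (Rattus norvegicus), read by scintillation counting; on this read-out lower numbers stand for stronger inhibition and higher numbers for weaker inhibition:

Compound 1 `O=C(Nc1nc(-c2ccccc2)nc2c1nnn2Cc1ccccc1)c1cccc([N+](=O)[O-])c1` gives 77 nM.
Compound 2 `O=C(Nc1nc(-c2ccccc2)nc2c1nnn2Cc1ccccc1)c1ccccc1C(F)(F)F` gives 550 nM.
Compound 3 `Cc1ccc(C(=O)Nc2nc(-c3ccccc3)nc3c2nnn3Cc2ccccc2)cc1` gives 709 nM.

Among these three numbers compound 2 holds the second highest. Its nearest neighbour is compound 3, the step of a 1.3-fold higher number from compound 2 to compound 3 (0.11 log units; within the scatter) lying within the scatter, so no order between compound 2 and compound 3 can be claimed. Its furthest neighbour is compound 1, where a 7.1-fold higher number from compound 1 to compound 2 (0.85 log units; beyond the scatter) is beyond the scatter. Compound 4 `O=C(Nc1nc(-c2ccccc2)nc2c1nnn2Cc1ccccc1)c1ccccc1F` differs from compound 2 in one place: fluoro in place of trifluoromethyl on an aromatic carbon.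

Within the data shown here, two measured steps bear on this change, since each of them also alters the substituent on the ring attached to the carbonyl: a 7.1-fold higher number from compound 1 to compound 2 (0.85 log units; beyond the scatter) and a 1.3-fold higher number from compound 2 to compound 3 (0.11 log units; within the scatter). The former is modest and beyond the scatter, the latter within it. Among the measured compounds shown here, no measured step swaps trifluoromethyl for fluoro, so the expectation rests on the observation that exchanging one substituent on that ring for another, compound 1 aside, moved the number little. The step of a 1.2-fold lower number from compound 2 to compound 4 (0.09 log units; within the scatter) is therefore expected to stay within or near the scatter, with no clear direction. Compound 4 is estimated at 450 nM, in a range from 150 nM to 1300 nM.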

Compound 4, inhibition constant: 40 nM
Compound 4: middle estimate off by 11-fold (1.05 log units), on the high side, outside the stated range (below it).
By their numbers in this assay, from the lowest: compounds 4 and 1 (each within the scatter of the next); then compounds 2 and 3 (each within the scatter of the next).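

In this assay, among these compounds, the aromatic carbon ortho to a large group proves highly sensitive to its substituent: fluoro in place of trifluoromethyl, one heavy atom in place of four, gives a 14-fold lower number from compound 2 to compound 4 (1.14 log units; beyond the scatter), a large step that the earlier compounds gave no sign of. The 2-fluorophenyl group also separates clearly from the 4-methylphenyl group, with an 18-fold lower number from compound 3 to compound 4 (1.25 log units; beyond the scatter), whereas a 1.9-fold lower number from compound 1 to compound 4 (0.28 log units; within the scatter) lies within the scatter, so no order can be claimed for that pair, and the four compounds fall into two levels, compounds 4 and 1 in one and compounds 2 and 3 in the other. Nothing available bears on what lies behind the large step from trifluoromethyl to fluoro.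

Going by these compounds, it remains open whether chloro, methyl or methoxy at this same place would stand with compound 4 or with compound 2, and where the plain phenyl ring would fall. Also open, on these data alone, is whether fluoro on another carbon of that ring would keep the number of compound 4, or whether the gain belongs to this place alone.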